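Ester variation on the shared core: cytotoxicity working notes

The compounds below may be only part of what the source reports. "The series", "measured", "known", "first", "only" and "open" are said of these compounds alone.

Measured so far:
compound 1 `CCOCC(=O)OCCc1c(-c2ccccc2Cl)c2cc(Cl)ccc2[nH]c1=O`: 130000 nM
compound 2 `CC(=O)OCC(=O)OCCc1c(-c2ccccc2Cl)c2cc(Cl)ccc2[nH]c1=O`: 100000 nM
compound 3 `O=C(OCCc1c(-c2ccccc2Cl)c2cc(Cl)ccc2[nH]c1=O)c1ccc([N+](=O)[O-])cc1`: 1600000 nM

In an ADME assay on HepG2 2.2.15 cells (Homo sapiens) for cytotoxicity (a higher number here means that more compound is tolerated, a lower number that less compound is tolerated), compound 3 gives the highest of the three numbers; compound 1 stands nearest, a 12-fold higher number from compound 1 to compound 3 (1.09 log units; beyond the scatter), and compound 2 furthest, a 16-fold higher number from compound 2 to compound 3 (1.20 log units; beyond the scatter). Compound 4 `O=C(/C=C/c1cccnc1)OCCc1c(-c2ccccc2Cl)c2cc(Cl)ccc2[nH]c1=O` is still to be measured. The change from compound 3 is 2-(pyridin-3-yl)ethenyl in place of 4-nitrophenyl on a carbonyl carbon. Both measured steps onto compound 3 altered the group on this same carbonyl carbon and were large, so this assay responds strongly to that position. Compound 4 keeps an aromatic ring there but loses the 4-nitrophenyl that went with the rise; a partial fall back toward compounds 1 and 2 is expected. Compound 4 is estimated at 500000 nM (range 150000 nM to 1600000 nM). That estimate corresponds to an expected step of a 3.2-fold lower number from compound 3 to compound 4 (0.51 log units; beyond the scatter).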

Compound 4, half-maximal cytotoxic concentration: 39000 nM
For compound 4 the middle estimate is 13-fold (1.11 log units) above the measured one; the measured number lies below the stated range.
By their numbers in this assay, from the lowest: compound 4; then compounds 2 and 1 (each within the scatter of the next); then compound 3.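

In this assay, an aromatic ring on this carbonyl carbon does not by itself carry the high number: 2-(pyridin-3-yl)ethenyl in place of 4-nitrophenyl gives a 41-fold lower number from compound 3 to compound 4 (1.61 log units; beyond the scatter). The same group also falls under ethoxymethyl and acetoxymethyl, with a 3.3-fold lower number from compound 1 to compound 4 (0.52 log units; beyond the scatter) and a 2.6-fold lower number from compound 2 to compound 4 (0.41 log units; beyond the scatter), so changes at this position move the number in both directions. No measurement at hand offers a reason for these steps.

The change swaps the ring and adds the ethenyl link at once, so their shares stay unseparated. Plain phenyl or pyridin-3-yl directly on the carbonyl carbon would leave open questions answerable, as would 4-aminophenyl for the nitro group.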